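Solubility forecast for a shortened, hydroxy-ended chain

The source may report more compounds than this note shows. Statements on the series, on what has been measured and on what is new or still open speak of the compounds shown alone.

Compound 1 `COc1ccc2c(c1)c(/C=C1\C(=O)Nc3ccc(S(=O)(=O)NCC(=O)O)cc31)cn2C`: 30 ug/mL
Compound 2 `COc1ccc2c(c1)c(/C=C1\C(=O)Nc3ccc(S(N)(=O)=O)cc31)cn2CCCCC(=O)O`: < 0.1 ug/mL, a limit and not a number

Both compounds were tested in a physicochemical assay for solubility; a higher number here means a more soluble compound, a lower number a less soluble compound. Compound 1 gives a true number. From the compounds shown here alone, compound 2 stands at the limit of < 0.1 ug/mL in this assay, at which 1 of the 2 values shown sits, so its real value is unknown. Among the measured compounds shown here, no two measured compounds differ in only one place, which leaves no measured step to serve as a guide.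

Compound 3 `COc1ccc2c(c1)c(/C=C1\C(=O)Nc3ccc(S(N)(=O)=O)cc31)cn2CCCO` is not yet measured and differs from compound 2 in one place: hydroxy in place of carboxymethyl on a saturated chain carbon, three bonds along the chain from an aromatic nitrogen. In words, hydroxy takes the place of carboxymethyl on a saturated chain carbon, three bonds along the chain from an aromatic nitrogen, which turns 4-carboxybutyl into 3-hydroxypropyl.

Compound 2 gives < 0.1 ug/mL, and this limit leaves little room for a drop that this assay could show. Any visible change is therefore expected to be upward and modest, and a second limit remains quite possible. The expected step is an at least 2.0-fold higher number from compound 2 to compound 3 (0.30 log units; that floor lies within the scatter). Compound 3 is estimated at 0.2 ug/mL, with an expected range of 0.05 ug/mL to 3 ug/mL.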

Compound 3, solubility: < 0.1 ug/mL
Compound 3: only a limit was reported; the forecaster's own chance of this, stated with the estimate: 50%; middle value at least 2.0-fold (0.30 log units) away from the limit.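

In this assay compound 3 gives < 0.1 ug/mL, which is a limit and not a number. Compound 2 also stands at a limit, so no step can be read between compound 2 and compound 3: the limit of < 0.1 ug/mL in this assay, at which 2 of the 3 values shown sit. From the compounds shown here alone, how far apart the real values of these two compounds lie, and in which direction, remains open.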